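The source may hold more compounds than are shown below. What is called first, only, known or untested is meant among the compounds shown, and "the series" means these compounds.

Measured so far in a functional assay on CHO cells for agonist activity at Free fatty acid receptor 2 (Homo sapiens), read by cAMP accumulation; on this read-out lower numbers stand for stronger inhibition and higher numbers for weaker inhibition:

compound 1, `CC(C)[C@H](C(=O)NCc1ccccc1)c1ccc(Cl)cc1`: > 100000 nM, a limit of the assay
compound 2, `CC(C)[C@H](C(=O)Nc1ccccc1)c1ccc(Cl)cc1`: > 100000 nM, a limit of the assay
compound 3, `CC(C)[C@H](C(=O)Nc1cccnn1)c1ccc(Cl)cc1`: 2300 nM

Within the data shown here, compound 3 stands alone as the only number among the three values; the two other entries are limits, namely (the limit of > 100000 nM in this assay, at which 2 of the 3 values shown sit). The step that the two limits leave unreadable from compound 1 to compound 2 cannot be read because both ends sit at that limit. The steps of an at least 43-fold lower number from compound 1 to compound 3 (1.63 log units; beyond the scatter) and an at least 43-fold lower number from compound 2 to compound 3 (1.63 log units; beyond the scatter) are both large and point the same way: a pyridazin-3-yl on the amide-type nitrogen gives a far lower number than either a benzyl or a phenyl there.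

Compound 4, `CC(C)[C@H](C(=O)Nc1ncns1)c1ccc(Cl)cc1`, carries the change (1,2,4-thiadiazol-5-yl in place of pyridazin-3-yl on an amide-type nitrogen). Among the measured compounds shown here, no measured pair covers a move from one small aromatic heterocycle to another on this nitrogen; the measured steps only show that a heteroaromatic ring on the amide-type nitrogen is strongly favoured over the two carbocyclic groups. Compound 4 keeps such a ring, so the expectation is a step near the scatter, a 1.1-fold higher number from compound 3 to compound 4 (0.04 log units; within the scatter). Compound 4 is therefore estimated to give 2500 nM in this assay, within a range of 600 nM to 10000 nM.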

Compound 4, half-maximal inhibitory concentration: 2000 nM
For compound 4 the middle estimate is 1.3-fold (0.10 log units) above the measured one, and the stated range covers the measured number.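

Replacing pyridazin-3-yl with 1,2,4-thiadiazol-5-yl on the amide-type nitrogen gives a 1.2-fold lower number from compound 3 to compound 4 (0.06 log units; within the scatter) in this assay, so a five-membered aromatic ring containing sulfur serves here as well as a six-membered aromatic ring with 2 hetero atoms. The large distance from the carbocyclic groups is also reproduced by this second heteroaromatic ring, with an at least 50-fold lower number from compound 2 to compound 4 (1.69 log units; beyond the scatter) and an at least 50-fold lower number from compound 1 to compound 4 (1.69 log units; beyond the scatter). Among these compounds, the earlier compounds tied that distance to pyridazin-3-yl alone, whereas it now holds for two rings that differ in size and in their hetero atoms, although these two rings are the only evidence for it.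

Going by these compounds, compound 1 and compound 2 still cannot be ordered against each other, and the size of every step from them remains unreadable beyond the printed minimum: the limit of > 100000 nM in this assay, at which 2 of the 4 values shown sit. Also open is whether a ring with a single nitrogen, such as pyridin-2-yl, or a thiazol-2-yl on the same nitrogen would keep these low numbers, and whether a carboxylic acid or an amine attached to either heteroaromatic ring would move them.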